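The compounds below may be only part of what the source reports. "The series", "measured", "known", "first", "only" and "open" are said of these compounds alone.

Compound 1 `CCN(C)c1nc(Cc2c(F)cccc2F)c(C)c(=O)[nH]1`: > 85000 nM
Compound 2 `CCCN(CCC)c1nc(Cc2c(F)cccc2F)c(C)c(=O)[nH]1`: > 74000 nM
Compound 3 `Cc1c(Cc2c(F)cccc2F)nc(N2CCCC2)[nH]c1=O`: > 82000 nM

All three compounds were tested in an ADME assay on MT4 cells (Homo sapiens) for cytotoxicity, read by MTT assay, with a stated time of 4 days; on this read-out higher numbers stand for lower toxicity in this test and lower numbers for higher toxicity in this test. Compound 3 gives > 82000 nM, which is a limit and not a number. The other two values are limits as well.

Compound 4 `Cc1c(Cc2c(F)cccc2F)nc(N2CCCC(C)C2)[nH]c1=O` carries 3-methylpiperidin-1-yl in place of pyrrolidin-1-yl on an aromatic carbon.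

The nearest evidence is a step that the two limits leave unreadable from compound 1 to compound 3, together with a step that the two limits leave unreadable from compound 2 to compound 3 and a step that the two limits leave unreadable from compound 1 to compound 2. None of these has a readable size, so they give no direction. All they show is that these three groups on the shared core gave no number in this assay.

The expected change is none beyond the scatter, an estimated at least 1.1-fold lower number from compound 3 to compound 4 (0.05 log units; that floor lies within the scatter). Another limit is the likeliest result. For compound 4 the estimated value is 72000 nM, with an expected range from 30000 nM to 100000 nM.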

Compound 4, half-maximal cytotoxic concentration: > 75000 nM
Compound 4: a limit, no number; the forecaster's own chance of this, stated with the estimate: 75%; middle value at least 1.0-fold (0.01 log units) from the limit.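

Compound 4, like compound 1, compound 2 and compound 3, gives only a limit, and the steps to compound 4 from these three cannot be read. The compounds shown leave open at what concentration any of the four would reach a half-maximal cytotoxic effect in this assay.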